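A Chlorophenyl Replaces a Methylphenyl on the Aromatic Nitrogen

The source may report more compounds than this note shows. Statements on the series, on what has been measured and on what is new or still open speak of the compounds shown alone.

Of the compounds shown here, three sharing one core have been measured in a functional assay on OVCAR-3 cells (Homo sapiens) for antiproliferative activity, read by MTT assay, with a stated time of 24 h; a lower number here means a stronger inhibitor, a higher number a weaker inhibitor. Compound 1 `Cc1ccccc1-n1cc(-c2ccccc2NS(=O)(=O)c2c[nH]c(=O)[nH]c2=O)nn1` gives 6550 nM, compound 2 `O=c1[nH]cc(S(=O)(=O)Nc2ccccc2-c2cn(-c3ccc(Cl)cc3)nn2)c(=O)[nH]1` gives 1750 nM, and compound 3 `Cc1cccc(-n2cc(-c3cccc(NS(=O)(=O)c4c[nH]c(=O)[nH]c4=O)c3)nn2)c1` gives 4080 nM. Compound 3 thus has the second highest of the three numbers; its gap to compound 1 lies within the scatter, while compound 2 lies beyond the scatter below it. Compound 4 `O=c1[nH]cc(S(=O)(=O)Nc2cccc(-c3cn(-c4ccccc4Cl)nn3)c2)c(=O)[nH]1` differs from compound 3 by 2-chlorophenyl in place of 3-methylphenyl on an aromatic nitrogen. For the measured compounds named here, the only measured step that bears on this swap is a 3.7-fold lower number from compound 1 to compound 2 (0.57 log units; beyond the scatter), where a chlorophenyl likewise replaced a methylphenyl, though the groups there carried their substituents differently. A modest step in the same direction is therefore expected, a 1.6-fold lower number from compound 3 to compound 4 (0.21 log units; within the scatter). Compound 4 is estimated at 2500 nM, with a range from 1000 nM to 6500 nM.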

Compound 4, half-maximal inhibitory concentration: 5370 nM
For compound 4 the middle estimate is 2.1-fold (0.33 log units) below the measured one; the measured number falls inside the stated range.
By their numbers in this assay, from the lowest: compound 2; then compounds 3, 4 and 1 (each within the scatter of the next).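

In this assay the swap to 2-chlorophenyl on this aromatic nitrogen gives a 1.3-fold higher number from compound 3 to compound 4 (0.12 log units; within the scatter) and so makes no readable difference. A chlorophenyl in place of a methylphenyl therefore does not always repeat a 3.7-fold lower number from compound 1 to compound 2 (0.57 log units; beyond the scatter) in size, and compound 4 is the case that goes against it. No measured evidence here accounts for the contrast between these two swaps.
The compounds shown do not separate the change from methyl to chlorine from the shift in where that substituent sits on the phenyl ring. As far as these compounds go, how a phenyl ring carrying an amine or a carboxylic acid would read on this nitrogen remains open.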